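Methylsulfanyl in Place of a Hydroxylated Branch on the Acid Chain

This account rests on a few compounds, and the source may have more. Where it says the series, first, only, none or still open, it means among the compounds named here.

Compound 1 `CC(C)(O)C(CCC/C=C(\c1ccccc1)c1cccnc1)C(=O)O` — 42 nM
Compound 2 `O=C(O)CCCC/C=C(\c1cccnc1)c1ccsc1` — 31 nM
Compound 3 `O=C(O)CCCC/C=C(\c1cccnc1)c1cccc([N+](=O)[O-])c1` — 73 nM

Of the compounds shown here, three have been measured in an assay (Equus caballus) for inhibition of Thromboxane-A synthase (Homo sapiens), using microsomes; on this read-out higher numbers stand for weaker inhibition and lower numbers for stronger inhibition. Compound 1 gives 42 nM in this assay, which places it second highest of the three numbers. Its nearest neighbour is compound 2, with 31 nM, and the gap between the two lies within the scatter of repeated measurements. The furthest is compound 3, with 73 nM, and that gap also stays within the scatter. On these numbers, then, none of the three can be singled out as the stronger or weaker inhibitor; they sit in one band.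

Compound 4 `CSC(CCC/C=C(\c1ccccc1)c1cccnc1)C(=O)O` has not yet been measured in this assay. It differs from compound 1 in one place: methylsulfanyl in place of 1-hydroxy-1-methylethyl on a saturated chain carbon bound to a carbonyl carbon and a saturated chain carbon. Going by the values given here, no pair of measured compounds shows this kind of change, so there is no measured step to lean on. What is known is that compound 1 itself gives 42 nM and that the three measured compounds all fall close together. On that footing, the step from compound 1 to compound 4 is expected to be small, a 1.4-fold higher number from compound 1 to compound 4 (0.15 log units; within the scatter), likely not beyond the scatter, with a slight lean toward a higher number. Compound 4 is therefore estimated at 60 nM in this assay, with a range from 15 nM to 240 nM.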

Compound 4, half-maximal inhibitory concentration: 30 nM
Compound 4: middle estimate off by 2.0-fold (0.30 log units), on the high side, and the stated range covers the measured number.
By their numbers in this assay, from the lowest: compounds 4, 2, 1 and 3 (each within the scatter of the next, the first and the last beyond it).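

In this assay, going by these compounds alone, this is the first measured step at this position: methylsulfanyl in place of 1-hydroxy-1-methylethyl, on a saturated chain carbon bound to a carbonyl carbon and a saturated chain carbon, gives a 1.4-fold lower number from compound 1 to compound 4 (0.15 log units; within the scatter). Within the data shown here, the group that leaves has 4 heavy atoms and 1 hydrogen-bond donor, the group that enters has 2 heavy atoms and 0 hydrogen-bond donors, and this exchange stays inside the scatter, which the earlier compounds, with no step between them, could not show. Nothing available explains this outcome or links it to any property of either group.

On these data alone, a single step cannot say how far this position would accept other groups, so the effect of an amine, a hydroxyl alone or a longer ethylsulfanyl group in the same place remains open. As far as these compounds go, it also remains open whether methylsulfanyl would read the same way on the core of compound 2 or compound 3, where the acid chain carries no such group.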